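From methylsulfanyl to ethylsulfanyl at the assay limit

A few compounds are considered here, and "the series" means these few. Any claim that something is new, unique, unknown or untested is made for them only; others in the source may bear on it.

Measured so far in a functional assay on HT-29 cells (Homo sapiens) for inhibition, read by MTT assay, with a stated time of 48 h (on this read-out higher numbers stand for weaker inhibition and lower numbers for stronger inhibition), with every value a limit of the assay:
- compound 1 `CCSc1nnc(-c2cc(OC)c(OC)c(OC)c2)n1-c1ccc(OC)cc1` gives > 60000 nM (a limit)
- compound 2 `COc1cc(-c2nnc(S)n2-c2ccc(N(C)C)cc2)cc(OC)c1OC` gives > 60000 nM (a limit)
- compound 3 `COc1cc(-c2nnc(SC)n2-c2ccc(N(C)C)cc2)cc(OC)c1OC` gives > 60000 nM (a limit)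

Compound 3 stands at > 60000 nM as a limit and not a number. The other two measured compounds are limits as well (the limit of > 60000 nM in this assay, at which 3 of the 3 values shown sit), so the figures give no ranking among the three.

The change to compound 4 `CCSc1nnc(-c2cc(OC)c(OC)c(OC)c2)n1-c1ccc(N(C)C)cc1` is methyl in place of hydrogen on a saturated chain carbon bound to a sulfur, which turns methylsulfanyl into ethylsulfanyl (methyl in place of hydrogen on a saturated chain carbon bound to a sulfur).

Among the compounds with values here, the one measured step that bears on this is a step that the two limits leave unreadable from compound 2 to compound 3 and it concerns methyl in place of hydrogen on a sulfur. Both ends of that step are limits, so it offers no size and no direction to carry over. No step beyond the scatter is therefore expected in this assay, and no direction is assigned. The expected step is a number no higher from compound 3 to compound 4 (the limit leaves the size open) and the likeliest report is the same limit again. For compound 4 the estimate is 60000 nM with an expected range from 8000 nM to 100000 nM as the span for a reported number.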

Compound 4, half-maximal inhibitory concentration: > 60000 nM
Compound 4: a limit, no number; the forecaster's own chance of this, stated with the estimate: 75%; the middle value lies on the limit itself.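

In this assay compound 4 gives > 60000 nM as a limit and not a number. No step from compound 1, compound 2 or compound 3 to compound 4 can be read: the limit of > 60000 nM in this assay, at which 4 of the 4 values shown sit.

The compounds shown leave open whether methylsulfanyl, ethylsulfanyl or dimethylamino in place of methoxy makes any difference to inhibition in this assay at all.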